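Removing the 4-fluorophenyl from compound 2

This account rests on a few compounds, and the source may have more. Where it says the series, first, only, none or still open, it means among the compounds named here.

Compound 2 `CC(C)=CCOc1c(C)c(C)c2c(c1C)CCC(C)(COc1ccc(/C=C3\SC(=O)NC3=O)cc1-c1ccc(F)cc1)O2` is measured in a functional assay on MCF7 cells (Homo sapiens), tested at 5 uM (a lower number here means a stronger effect, a higher number a weaker effect of the compound at the concentration tested), at 92%. Compound 3 `C=CCOc1c(C)c(C)c2c(c1C)CCC(C)(COc1cccc(/C=C3\SC(=O)NC3=O)c1)O2` gives 92%, level with compound 2 at the digits shown, and together they are the highest of the three numbers. Compound 1 `CC(C)=CCOc1c(C)c(C)c2c(c1C)CCC(C)(COc1ccc(/C=C3\SC(=O)NC3=O)cc1C)O2` gives 56%, and the step of a number 36 percentage points higher from compound 1 to compound 2 (beyond the scatter) is large, beyond the scatter. Compound 4 `CC(C)=CCOc1c(C)c(C)c2c(c1C)CCC(C)(COc1ccc(/C=C3\SC(=O)NC3=O)cc1)O2` differs from compound 2 by hydrogen in place of 4-fluorophenyl on an aromatic carbon. Going by the values given here, the only step that bears on this change is the one from compound 1 to compound 2, where the 4-fluorophenyl entering raised the read-out by a number 36 percentage points higher from compound 1 to compound 2 (beyond the scatter). Its removal is therefore expected to lower the read-out, with compound 4 estimated at 65% in this assay, in the range 45% to 92%, a step of a number 27 percentage points lower from compound 2 to compound 4 (beyond the scatter).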

Compound 4, a percentage reported as activity, at one concentration (the size of the read-out at that concentration, not a potency): 21%
The estimate for compound 4 lay 44 percentage points above the measured number; measured number below the stated range.
By their numbers in this assay, from the lowest: compound 4; then compound 1; then compounds 2 and 3 (each within the scatter of the next).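

At this aromatic carbon, hydrogen outdoes both substituents in this assay, with a step of a number 71 percentage points lower from compound 2 to compound 4 (beyond the scatter) and another of a number 35 percentage points lower from compound 1 to compound 4 (beyond the scatter). The methyl of compound 1, which looked favourable beside the 4-fluorophenyl, thus also weakens the effect relative to hydrogen, so both groups shown here cost effect at this position. Nothing available accounts for these steps. On these data alone, whether a smaller atom such as fluorine, or a hydroxyl or methoxy group, would keep the effect of compound 4 remains open.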